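Enlarging the Amide Substituent on a Shared Core

This account rests on a few compounds, and the source may have more. Where it says the series, first, only, none or still open, it means among the compounds named here.

Measured compounds:
Compound 1 `CCC1C(=O)N(C)c2cnc(-n3ccc4cc(C(=O)NC)ccc43)nc2N1c1ccn(C)n1`: 6330 nM in a functional assay on HeLa cells (Homo sapiens) for antiproliferative activity, read by CCK-8 assay, with a stated time of 72 h; a higher number here means a weaker inhibitor of growth, a lower number a stronger inhibitor of growth
Compound 2 `CCC1C(=O)N(C)c2cnc(-n3ccc4cc(C(=O)NC(C)C)ccc43)nc2N1c1ccn(C)n1`: 4350 nM in this assay

Compound 2 has the lowest of the two numbers shown; its nearest neighbour is compound 1, and the only measured step between them is a 1.5-fold lower number from compound 1 to compound 2 (0.16 log units; within the scatter), which lies within the usual scatter of this measurement. The two compounds therefore cannot be ranked against each other.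

Compound 3 `CCC1C(=O)N(C)c2cnc(-n3ccc4cc(C(=O)NC5CCCC5)ccc43)nc2N1c1ccn(C)n1` has not yet been measured. It differs from compound 2 by cyclopentyl in place of isopropyl on an amide-type nitrogen. Within the data shown here, the one measured step that bears on this change is a 1.5-fold lower number from compound 1 to compound 2 (0.16 log units; within the scatter): there too a larger group replaced a smaller one on the same amide-type nitrogen, and the number moved only within the scatter. With a single such step to go on, the expectation for a further enlargement is a change of similar size at most, if any, in this assay.

Compound 3 is therefore expected to give about 3500 nM, within a range of 1500 nM to 8000 nM. The expected step of a 1.2-fold lower number from compound 2 to compound 3 (0.09 log units; within the scatter) is estimated to stay within the scatter.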

Compound 3, concentration for 50% growth inhibition: 27400 nM
Compound 3: the middle estimate sits 7.8-fold (0.89 log units) below what was measured; measured number outside the range, above it.
By their numbers in this assay, from the lowest: compounds 2 and 1 (each within the scatter of the next); then compound 3.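

In this assay, the group on this amide-type nitrogen turns out to matter: cyclopentyl in place of isopropyl gives a 6.3-fold higher number from compound 2 to compound 3 (0.80 log units; beyond the scatter) and cyclopentyl in place of methyl gives a 4.3-fold higher number from compound 1 to compound 3 (0.64 log units; beyond the scatter) and, with both steps beyond the scatter, compound 3 is the weakest inhibitor of growth of the three. The response to enlarging this group is also uneven, since the change from methyl to isopropyl stayed within the scatter, while the further change to cyclopentyl, which adds a five-membered ring, did not. Nothing among the results shown explains why the number rises with cyclopentyl.

Among these compounds, with only these three groups, size and the presence of a ring cannot be told apart, since the one group that raises the number is both the largest and the only cyclic one. On these data alone, an open chain such as n-pentyl, a smaller ring such as cyclopropyl, or a cyclopentyl ring carrying an amine would each help to separate these possibilities, and how any of them would behave at this nitrogen remains open.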